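The compounds below may be only part of what the source reports. "The series", "measured", "known", "first", "only" and "open" are said of these compounds alone.

Measured compounds:
- compound 1 `COc1ccc(-c2cc(=O)c3c(OC)cc(OC)cc3n2S(=O)(=O)c2ccc(Cl)cc2)cc1`; in an ADME assay on BJ cells (Homo sapiens) for antiproliferative activity, with a stated time of 72 h (a higher number here means that more compound is needed for the effect, a lower number that less compound is needed), compound 1 gives > 34400 nM, a limit.
- compound 2 `COc1cc(OC)c2c(=O)cc(C(=O)Nc3ccc(Oc4ccc([N+](=O)[O-])cc4)cc3)[nH]c2c1`; compound 2 gives > 22900 nM, a limit.
- compound 3 `COc1cc(OC)c2c(=O)cc(C(=O)Nc3ccc(Oc4ccc(F)cc4)cc3)[nH]c2c1`; compound 3 gives > 50000 nM, a limit.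

Compound 3 sits only at a limit, (the limit of > 50000 nM in this assay, at which 1 of the 3 values shown sits), and the two other values shown are limits as well. Going by the values given here, the one measured step, a step that the two limits leave unreadable from compound 2 to compound 3, cannot be read because both ends are limits. Compound 4 `COc1cc(OC)c2c(=O)cc(C(=O)Nc3ccc(S(=O)(=O)c4ccccc4)cc3)[nH]c2c1` differs from compound 3 by phenylsulfonyl in place of 4-fluorophenoxy on an aromatic carbon. Among the compounds with values here, no measured step bears on this change, so no direction beyond the scatter is expected; compound 4 is expected to stay at the limit as well, an expected step of a number no higher from compound 3 to compound 4 (the limit leaves the size open). The estimate for compound 4 is 50000 nM, with a range from 20000 nM to 100000 nM.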

Compound 4, half-maximal effective concentration: > 70600 nM
Compound 4: only a limit was reported; the forecaster's own chance of this, stated with the estimate: 80%; at least 1.4-fold (0.14 log units) between middle value and limit.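

In this assay compound 4 gives > 70600 nM, a limit. Going by these compounds alone, compound 3 gives > 50000 nM, also a limit, and compound 2 gives > 22900 nM, again a limit, so no step from compound 2 or compound 3 to compound 4 can be read. The compounds shown leave open whether the phenylsulfonyl group changes the read-out at all, since none has a value other than a limit.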